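A few compounds are considered here, and "the series" means these few. Any claim that something is new, unique, unknown or untested is made for them only; others in the source may bear on it.

Measured so far in a functional assay on ACHN cells (Homo sapiens) for cytotoxicity, read by sulforhodamine B assay, with a stated time of 48 h, tested at 100 uM; on this read-out higher numbers stand for a weaker effect at the one concentration tested and lower numbers for a stronger effect:
compound 1 `COc1cc(-c2cc(/C=C/C(=O)c3ccc(N)cc3)[nH]n2)cc(OC)c1OC` gives -63%
compound 2 `COc1ccc(-c2cc(/C=C/C(=O)c3cc(OC)c(OC)c(OC)c3)[nH]n2)cc1OC` gives -84%

Compound 1 stands as the higher of the two numbers; compound 2 sits a step beyond the scatter lower, the two structures differing in more than one place, so only their values are compared. Compound 3 `COc1ccc(C(=O)/C=C/c2cc(-c3cc(OC)c(OC)c(OC)c3)n[nH]2)cc1OC` is not yet measured. It differs from compound 1 by 3,4-dimethoxyphenyl in place of 4-aminophenyl on a carbonyl carbon. Among the compounds with values here, no single-point step is known, so the expected step of a number 7 percentage points lower from compound 1 to compound 3 (within the scatter) is set small and downward, close to the edge of the scatter. For compound 3 the estimate in this assay is -70%, with a range from -90% to -45%.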

Compound 3, a percentage reported as activity, at one concentration (the size of the read-out at that concentration, not a potency): -91%
Compound 3: middle estimate off by 21 percentage points, on the high side; the whole stated range lies above it.
By their numbers in this assay, from the lowest: compounds 3 and 2 (each within the scatter of the next); then compound 1.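

In this assay, within the data shown here, 3,4-dimethoxyphenyl in place of 4-aminophenyl on the carbonyl carbon gives a number 28 percentage points lower from compound 1 to compound 3 (beyond the scatter), the first single-place comparison. The values of compound 1 and compound 2 could not show this, as those structures differ in more than one place. The group on this carbonyl carbon therefore affects the read-out, but no measurement available here accounts for the step.

As far as these compounds go, whether the step follows from losing 4-aminophenyl or gaining 3,4-dimethoxyphenyl remains open. An unsubstituted phenyl or a 4-methoxyphenyl on the same carbonyl carbon would help separate the two.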